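A few compounds are considered here, and "the series" means these few. Any claim that something is new, unique, unknown or untested is made for them only; others in the source may bear on it.

Measured in a functional assay on HCT-116 cells (Homo sapiens) for antiproliferative activity, read by MTT assay, with a stated time of 72 h; a higher number here means a weaker inhibitor, a lower number a stronger inhibitor:
Compound 1 `CCCC(=O)Nc1nc2ccc(NC(=O)CSc3ccc(Cl)cc3)cc2s1`: 2120 nM
Compound 2 `Cc1cc(C)cc(C(=O)Nc2nc3ccc(NC(=O)CSc4ccc(Cl)cc4)cc3s2)c1`: 65100 nM
Compound 3 `Cc1ccc(C(=O)Nc2nc3ccc(NC(=O)CSc4ccc(Cl)cc4)cc3s2)cc1`: 2120 nM

Compound 3 shares the lowest number of the three with compound 1, as the step of no change at the digits printed from compound 1 to compound 3 (within the scatter) shows. The remaining compound lies far off, with a 31-fold lower number from compound 2 to compound 3 (1.49 log units; beyond the scatter).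

Compound 4 `Cc1ccc(C(=O)Nc2nc3ccc(NC(=O)CSc4cccc(O)c4)cc3s2)cc1` keeps the 4-methylphenyl on the carbonyl carbon of compound 3 and carries 3-hydroxyphenyl in place of 4-chlorophenyl on a sulfur.

For the measured compounds named here, no measured step touches this place. All three steps in this assay concern the group on the carbonyl carbon, while the 4-chlorophenyl on the sulfur stays the same throughout. One of them is large, a 31-fold higher number from compound 1 to compound 2 (1.49 log units; beyond the scatter), and another stays within the scatter. Together they show that a single change in these compounds can leave the number unmoved or shift it a long way, but they fix neither a size nor a direction for the change at the sulfur.

With no direction to go on, no step beyond the scatter is expected, and the estimated step is a 1.3-fold higher number from compound 3 to compound 4 (0.12 log units; within the scatter). The large step seen with compound 2 argues for a wide range all the same. For compound 4 the estimated value is 2800 nM, with an expected range from 500 nM to 15000 nM.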

Compound 4, half-maximal inhibitory concentration: 7730 nM
Beside the measured number, compound 4's estimate is 2.8-fold (0.44 log units) below it, within the range that was stated.
By their numbers in this assay, from the lowest: compounds 1 and 3 (each within the scatter of the next); then compound 4; then compound 2.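

In this assay, this is the first change shown at the sulfur, and it gives a 3.6-fold higher number from compound 3 to compound 4 (0.56 log units; beyond the scatter), so this end of the molecule also affects the number, and the 3-hydroxyphenyl gives the weaker inhibitor of the pair. The two groups have the same count of heavy atoms, while the 3-hydroxyphenyl brings a hydrogen-bond donor and a hydrogen-bond acceptor that the 4-chlorophenyl lacks, so a swap of equal heavy-atom count is enough to move the number beyond the scatter, though only modestly. Nothing measured here accounts for the shift.

The swap changes both the atom on the ring and the name's ring position, so the compounds shown leave open whether 4-hydroxyphenyl or 3-chlorophenyl would sit nearer compound 3 or compound 4, and what an amine such as 3-aminophenyl would give at the same place. They also leave open whether the 3-hydroxyphenyl would have the same effect with propyl or 3,5-dimethylphenyl on the carbonyl carbon, given that those groups were compared only with the 4-chlorophenyl on the sulfur.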